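From 4-nitrophenyl to 3-chlorophenyl on the shared core

A few compounds are considered here, and "the series" means these few. Any claim that something is new, unique, unknown or untested is made for them only; others in the source may bear on it.

Measured in a functional assay on HeLa cells (Homo sapiens) for antiproliferative activity, read by MTT assay, with a stated time of 48 h (on this read-out higher numbers stand for weaker inhibition and lower numbers for stronger inhibition), so far, compound 1 (`O=[N+]([O-])c1cccc(-c2nn(-c3ccccc3)cc2C(Nc2nc3ccccc3s2)c2c(O)ccc3ccccc23)c1`) stands at 8220 nM and compound 2 (`O=[N+]([O-])c1ccc(-c2nn(-c3ccccc3)cc2C(Nc2nc3ccccc3s2)c2c(O)ccc3ccccc23)cc1`) at 6810 nM on the same core. Compound 2 lies within the scatter of compound 1, so the two are not ranked. Compound 3 (`Oc1ccc2ccccc2c1C(Nc1nc2ccccc2s1)c1cn(-c2ccccc2)nc1-c1cccc(Cl)c1`) carries 3-chlorophenyl in place of 4-nitrophenyl on an aromatic carbon of the five-membered aromatic ring with 2 nitrogen. Among the compounds with values here, only one measured step bears on this change, with 4-nitrophenyl in place of 3-nitrophenyl, and it is small. Within the data shown here, no measured compound carries 3-chlorophenyl, so the data hold no direct precedent for this group. Resting on the single step (a 1.2-fold lower number from compound 1 to compound 2 (0.08 log units; within the scatter)) no step beyond the scatter is expected in this assay and no direction is favoured, although the range must stay wide. Compound 3 is estimated at 6500 nM with an expected range from 2800 nM to 15000 nM for the measurement. The estimated change is a 1.0-fold lower number from compound 2 to compound 3 (0.02 log units; within the scatter) and remains an expectation only.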

Compound 3, half-maximal inhibitory concentration: 6830 nM
For compound 3 the middle estimate is 1.1-fold (0.02 log units) below the measured one; low and high end bracket the measured number.
By their numbers in this assay, from the lowest: compounds 2, 3 and 1 (each within the scatter of the next).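

Until now only the place of the nitro group on this phenyl ring had varied; compound 3 removes the nitro group itself. In this assay, 3-chlorophenyl in place of 4-nitrophenyl gives a 1.0-fold higher number from compound 2 to compound 3 (0.00 log units; within the scatter), and chloro in place of nitro on an aromatic carbon gives a 1.2-fold lower number from compound 1 to compound 3 (0.08 log units; within the scatter), so neither step separates the compounds and all three remain unranked. At this aromatic carbon of the five-membered ring, a group counted with hydrogen-bond acceptors and one counted without them therefore give numbers that cannot be told apart in this read-out, though no evidence bears on why this is so.

The compounds shown leave open whether an amine or a carboxylic acid on this phenyl ring, or a longer alkyl chain in place of the ring, would give a step beyond the scatter. Also open, going by these compounds, is whether a plain phenyl ring with neither chloro nor nitro would stay within the scatter of these three compounds.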